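Cytotoxicity limits in the series and the step to compound 4

The compounds below may be only part of what the source reports. "The series", "measured", "known", "first", "only" and "open" are said of these compounds alone.

Measured compounds in an ADME assay on cells (Homo sapiens) for cytotoxicity, read by resazurin assay, with a stated time of 5 days; a higher number here means that more compound is tolerated, a lower number that less compound is tolerated:
compound 1 `COc1ccc(-c2nc(CSc3cccc(Br)c3)nc3ccsc23)cn1` gives > 50000 nM, a limit of the assay.
compound 2 `COc1ccc(-c2nc(CSc3ccc(C(F)(F)F)cn3)nc3ccsc23)cn1` gives > 50000 nM, a limit of the assay.
compound 3 `CCC1=C(C(=O)OCC2CCCCC2)C(c2cccc(O)c2)NC(=O)N1` gives > 10000 nM, a limit of the assay.

Compound 1 stands at the limit of > 50000 nM in this assay, at which 2 of the 3 values shown sit, so its value is a limit and not a number. Compound 2 sits at the same limit. Compound 3 sits at the limit of > 10000 nM in this assay, at which 1 of the 3 values shown sits, also a limit. None of the values shown is a number, so no order among the compounds can be read from this assay, and no step between measured compounds is shown.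

Compound 4 `COc1ccc(-c2nc(CSc3cccc(Cl)c3Cl)nc3ccsc23)cn1` differs from compound 1 by 2,3-dichlorophenyl in place of 3-bromophenyl on a sulfur. Going by the values given here, no measured step in this assay shows what a change of this kind does, so the size of the step is taken from the standing of compound 1 alone. The step is expected to be a step that the limit leaves unreadable from compound 1 to compound 4, none beyond the scatter. For compound 4 the expected value is 60000 nM, in the range 20000 nM to 150000 nM, and it is expected that this assay again reports only a limit rather than a number.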

Compound 4, half-maximal cytotoxic concentration: > 50000 nM
Compound 4: a limit, no number; the forecaster's own chance of this, stated with the estimate: 80%; the middle value lies beyond the limit too.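

In this assay compound 4 gives > 50000 nM, a limit of the assay and not a number. Going by these compounds alone, compound 1 gives > 50000 nM, also a limit, and no step from compound 1 to compound 4 can be read. The compounds shown leave open at what concentration any of them becomes cytotoxic in this assay, and what 2,3-dichlorophenyl in place of 3-bromophenyl on a sulfur does there.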